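Methyl in place of acetyl on the nitrogen of compound 3

A few compounds are considered here, and "the series" means these few. Any claim that something is new, unique, unknown or untested is made for them only; others in the source may bear on it.

In an ADME assay on L6 cells (Rattus norvegicus) for cytotoxicity, read by resazurin assay, with a stated time of 70 h (on this read-out lower numbers stand for stronger inhibition and higher numbers for weaker inhibition), compound 1 `CC(=O)Oc1ccc2c(c1)C(C)=CC(C)(C)N2Cc1ccc(F)cc1` gives 29000 nM and compound 2 `COc1ccc(CN2c3ccc(OC(C)=O)cc3C(C)=CC2(C)C)cc1` gives 15000 nM on the shared core, and the step between them is a 1.9-fold lower number from compound 1 to compound 2 (0.29 log units; within the scatter) with methoxy in place of fluoro on an aromatic carbon. Compound 3 `CC(=O)Oc1ccc2c(c1)C(C)=CC(C)(C)N2C(C)=O` at 160000 nM has the highest number of the three.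

The change under study is methyl in place of acetyl on a nitrogen on an aromatic ring in a ring and leads to compound 4 `CC(=O)Oc1ccc2c(c1)C(C)=CC(C)(C)N2C` with methyl in place of acetyl on a nitrogen on an aromatic ring in a ring. Within the data shown here, one measured step touches that nitrogen: a 5.5-fold higher number from compound 1 to compound 3 (0.74 log units; beyond the scatter) with acetyl in place of 4-fluorobenzyl. Among the measured compounds shown here, no measured compound carries methyl there, so that step gives the direction only loosely. The step of a 1.9-fold lower number from compound 1 to compound 2 (0.29 log units; within the scatter) concerns an aromatic carbon and says nothing direct about the nitrogen.

A modest move to a lower number is therefore expected in this assay and should be smaller than the step that introduced acetyl. The expected step is a 2.3-fold lower number from compound 3 to compound 4 (0.36 log units; beyond the scatter) and remains uncertain. Compound 4 is estimated at 70000 nM with an expected range from 25000 nM to 190000 nM as the likely span.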

Compound 4, half-maximal inhibitory concentration: 41000 nM
Estimate against measurement, compound 4: 1.7-fold (0.23 log units) above, and the stated range covers the measured number.
By their numbers in this assay, from the lowest: compounds 2, 1 and 4 (each within the scatter of the next, the first and the last beyond it); then compound 3.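

In this assay the acetyl of compound 3 now stands apart on this nitrogen: the step of a 3.9-fold lower number from compound 3 to compound 4 (0.59 log units; beyond the scatter) shows that methyl, with its single heavy atom, is enough to leave the acetyl number behind, which the earlier step from the 4-fluorobenzyl compound could not show. Methyl and 4-fluorobenzyl cannot be told apart, as the step of a 1.4-fold higher number from compound 1 to compound 4 (0.15 log units; within the scatter) shows, so the 4-fluorophenyl part adds nothing readable here, whereas the step of a 2.7-fold higher number from compound 2 to compound 4 (0.44 log units; beyond the scatter) shows that the compound with the 4-methoxyphenyl part keeps a distinctly lower number than the methyl compound. No measurement shown here bears on the reason for these differences.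

Still open, from the compounds shown here alone, is whether ethyl or a longer alkyl chain on this nitrogen stays with methyl or moves towards the 4-methoxybenzyl compound, and whether a chain ending in an amine or a carboxylic acid fits either of them. Going by these compounds, it is also open whether another carbonyl group such as propanoyl or benzoyl repeats the high number of the acetyl compound, or whether that number belongs to acetyl alone.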